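The compounds below may be only part of what the source reports. "The series", "measured", "known", "first", "only" and "open" are said of these compounds alone.

The series shares one core; compound 2 `Cc1cc([C@H](C(=O)NC(C)C)N2C(=O)[C@@H](C3Cc4ccccc4C3)NC(=O)[C@H]2CC(C)C)oc1C` carries the 4,5-dimethylfuran-2-yl group on the saturated chain carbon bound to the amide-type nitrogen in the ring and the carbonyl carbon. In an assay on isolated protein for binding affinity to Oxytocin receptor (Homo sapiens) (on this read-out lower numbers stand for stronger inhibition and higher numbers for weaker inhibition), compound 2 gives 1.26 nM, the second highest of the three numbers in hand. Compound 3 `CC(C)C[C@@H]1C(=O)N[C@H](C2Cc3ccccc3C2)C(=O)N1[C@@H](C(=O)NC(C)C)c1cc(Br)cs1` gives 1 nM in this assay; the swap at that carbon brings a 1.3-fold lower number from compound 2 to compound 3 (0.10 log units; within the scatter). Going by the values given here, compound 1 `CC(C)C[C@@H]1C(=O)N[C@H](C2Cc3ccccc3C2)C(=O)N1[C@@H](C(=O)NC(C)(C)C)c1ccoc1` differs from compound 2 in two places; in this assay compound 1 gives 12.6 nM, so the widest spread in the set comes with a double change that no single step covers.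

Compound 4 `CC(C)C[C@@H]1C(=O)N[C@H](C2Cc3ccccc3C2)C(=O)N1[C@@H](C(=O)NC(C)C)c1coc(C(F)(F)F)n1` is the next step: a group of 9 heavy atoms (4 carbon, 1 nitrogen, 1 oxygen, 3 fluorine; one five-membered aromatic ring with 2 hetero atoms) in place of a group of 7 heavy atoms (6 carbon, 1 oxygen; one five-membered aromatic ring with 1 hetero atom), on a saturated chain carbon bound to an amide-type nitrogen in a ring and a carbonyl carbon. Among the compounds with values here, the only single-point step at this position, from compound 2 to compound 3, stayed within the scatter, which speaks for tolerance of varied aromatic groups there, but that step kept the ring make-up close, whereas the entering group changes the ring type and adds a trifluoromethyl. Within the data shown here, no measured step covers such a change. In this assay the step from compound 2 to compound 4 is expected to be a 2.4-fold higher number from compound 2 to compound 4 (0.38 log units; beyond the scatter), a modest move toward a higher number with wide uncertainty. Compound 4 is therefore estimated at 3 nM, with a range from 0.8 nM to 12 nM.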

Compound 4, inhibition constant: 0.159 nM
Compound 4: middle estimate off by 19-fold (1.28 log units), on the high side; the measured number lies below the stated range.
By their numbers in this assay, from the lowest: compound 4; then compounds 3 and 2 (each within the scatter of the next); then compound 1.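

At the saturated chain carbon bound to an amide-type nitrogen in a ring and a carbonyl carbon, the choice of aromatic group can shift the number in this assay beyond the scatter: the entering trifluoromethyl-bearing five-membered aromatic ring with 2 hetero atoms gives a 7.9-fold lower number from compound 2 to compound 4 (0.90 log units; beyond the scatter) and a 6.3-fold lower number from compound 3 to compound 4 (0.80 log units; beyond the scatter). The earlier step at this carbon, a 1.3-fold lower number from compound 2 to compound 3 (0.10 log units; within the scatter), suggested a flat response to the aromatic group, but the 4,5-dimethylfuran-2-yl and 4-bromothiophen-2-yl groups now both separate from the entering group, so that tolerance does not extend to a lack of sensitivity at this position. The step combines a change of ring with the arrival of trifluoromethyl, and nothing on hand accounts for the lower number or assigns it to either part.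

Still open, on these data alone, is how much of the step belongs to the ring and how much to its substituent, a question that a methyl or a nitrile in place of the trifluoromethyl on the same ring would address. Also open, as far as these compounds go, is whether the entering group gives a similar step when paired with the amide of compound 1.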